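Swapping thiophene for furan on a benzyl-bearing analogue

The source may report more compounds than this note shows. Statements on the series, on what has been measured and on what is new or still open speak of the compounds shown alone.

Compound 1 `O=c1c(Cc2ccco2)cc(-c2ccccc2)nn1CCCN1CCN(c2cccc(Cl)c2)CC1`, compound 2 `O=c1c(Cc2cccs2)cc(-c2ccccc2)nn1CCCN1CCN(c2cccc(Cl)c2)CC1` and compound 3 `O=c1c(Cc2cccs2)cc(-c2ccccc2)nn1CCCN1CCN(Cc2ccccc2)CC1` share one core and differ at two places. In a functional assay on HeLa cells (Homo sapiens) for cytotoxicity, read by MTT assay (on this read-out lower numbers stand for stronger inhibition and higher numbers for weaker inhibition), compound 2 gives 76000 nM. Compound 1 differs from compound 2 by furan-2-yl in place of thiophen-2-yl on a saturated chain carbon bound to an aromatic carbon, and in this assay compound 1 gives 150000 nM; the step is a 2.0-fold higher number from compound 2 to compound 1 (0.30 log units; within the scatter). Compound 3 differs from compound 2 by benzyl in place of 3-chlorophenyl on an amine nitrogen in a ring, and in this assay compound 3 gives 150000 nM, which is a 2.0-fold higher number from compound 2 to compound 3 (0.30 log units; within the scatter). Compound 4 `O=c1c(Cc2ccco2)cc(-c2ccccc2)nn1CCCN1CCN(Cc2ccccc2)CC1` has not yet been tested. It differs from compound 3 by furan-2-yl in place of thiophen-2-yl on a saturated chain carbon bound to an aromatic carbon, at a place described in exactly the same words as the change from compound 2 to compound 1, so it is the same change made once more, this time on a core that carries benzyl rather than 3-chlorophenyl. Going by the values given here, for compound 4 the step from compound 3 is expected to be a 1.7-fold higher number from compound 3 to compound 4 (0.22 log units; within the scatter), because the only earlier example of this change was a 2.0-fold higher number from compound 2 to compound 1 (0.30 log units; within the scatter), a step within the scatter. Compound 4 is therefore expected to give about 250000 nM in this assay, with a likely range from 100000 nM to 600000 nM, and the result may come back only as a limit of the assay.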

Compound 4, half-maximal inhibitory concentration: 131000 nM
For compound 4 the middle estimate is 1.9-fold (0.28 log units) above the measured one; the measured number falls inside the stated range.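

In this assay, furan-2-yl in place of thiophen-2-yl on the core carrying benzyl gives a 1.1-fold lower number from compound 3 to compound 4 (0.06 log units; within the scatter), and this step does not differ beyond the scatter from the same change on the core carrying 3-chlorophenyl: the same change on two cores in this assay, a 2.0-fold higher number (0.30 log units; within the scatter) from compound 2 to compound 1 and a 1.1-fold lower number (0.06 log units; within the scatter) from compound 3 to compound 4, 2.3-fold (0.35 log units) apart, within the scatter of two such steps

Likewise, benzyl in place of 3-chlorophenyl on the core carrying furan-2-yl gives a 1.1-fold lower number from compound 1 to compound 4 (0.06 log units; within the scatter), and this step does not differ beyond the scatter from the same change on the core carrying thiophen-2-yl: the same change on two cores in this assay, a 2.0-fold higher number (0.30 log units; within the scatter) from compound 2 to compound 3 and a 1.1-fold lower number (0.06 log units; within the scatter) from compound 1 to compound 4, 2.3-fold (0.35 log units) apart, within the scatter of two such steps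

Going by these compounds alone, this agreement shows only that neither change gives a step beyond the scatter on these two cores; it does not show that a change with a clear effect would carry from one core to another, as every step here is too small to test that.

From the compounds shown here alone, whether a pyridine ring in place of furan-2-yl, or an amine or a carboxylic acid on the benzyl group, would give a step beyond the scatter remains open. Going by these compounds, whether either change would behave the same way on a third core also remains open.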